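This account rests on a few compounds, and the source may have more. Where it says the series, first, only, none or still open, it means among the compounds named here.

Compound 1 `COc1cc(-c2cc(/C=C/C(=O)c3ccc(N)cc3)[nH]n2)cc(OC)c1OC` gives 44800 nM in a functional assay on NCI-H460 cells (Homo sapiens) for inhibition, read by sulforhodamine B assay, with a stated time of 48 h; a lower number here means that less compound is tolerated, a higher number that more compound is tolerated. Compound 2 `COc1ccc(-c2cc(/C=C/C(=O)c3ccc(N)cc3)[nH]n2)cc1OC` gives 10600 nM in this assay.

Compound 1 thus stands at the highest of the two numbers, with compound 2 below it by a 4.2-fold lower number from compound 1 to compound 2 (0.63 log units; beyond the scatter). Compound 3 `COc1cc(-c2cc(/C=C/C(=O)c3ccc(F)c(F)c3)[nH]n2)cc(OC)c1OC` differs from compound 1 by 3,4-difluorophenyl in place of 4-aminophenyl on a carbonyl carbon. Among the compounds with values here, the only measured step, that from compound 1 to compound 2, concerns a different part of the molecule, so no measured step bears on this change and its direction is uncertain. Compound 3 is therefore expected to stay near compound 1, the estimated step being a 1.5-fold lower number from compound 1 to compound 3 (0.17 log units; within the scatter). The estimate for compound 3 is 30000 nM, expected to fall between 8000 nM and 100000 nM.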

Compound 3, concentration lethal to 50% of the cells: 80400 nM
For compound 3 the middle estimate is 2.7-fold (0.43 log units) below the measured one; low and high end bracket the measured number.
By their numbers in this assay, from the lowest: compound 2; then compounds 1 and 3 (each within the scatter of the next).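

Replacing 4-aminophenyl with 3,4-difluorophenyl on the carbonyl carbon gives a 1.8-fold higher number from compound 1 to compound 3 (0.25 log units; within the scatter) in this assay and so leaves the two groups indistinguishable here. This holds although the entering group has no hydrogen-bond donors or acceptors, while the leaving group has one of each. No supporting measurement is available to explain this result. Still open, going by these compounds, is whether the same holds with the core of compound 2, and how a carboxylic acid or a nitrile would read on this carbonyl carbon.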